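Cytotoxicity notes: carbamoyl replacing phenylsulfonyl on the shared core

The source may report more compounds than this note shows. Statements on the series, on what has been measured and on what is new or still open speak of the compounds shown alone.

Compound 1 `O=C(c1cc(F)c(F)cc1F)N(CCCCCCN1C[C@H](O)[C@@H](O)[C@H](O)[C@H]1CO)C1CCCCC1` and compound 2 `O=S(=O)(c1ccccc1)N(CCCCCCN1C[C@H](O)[C@@H](O)[C@H](O)[C@H]1CO)C1CCCCC1` share the same amine-bearing core with a six-carbon chain to the polyhydroxylated ring. In an ADME assay on MDBK cells (Bos taurus) for cytotoxicity, read by MTT assay (a lower number here means that less compound is tolerated, a higher number that more compound is tolerated), compound 1 gives only a limit, > 500000 nM. In this assay, for the measured compounds named here, compound 2 gives 200000 nM, the only plain number in the set. Going by the values given here, the step of an at least 2.5-fold lower number from compound 1 to compound 2 (0.39 log units; beyond the scatter) is the sole measured change, and it leans on (the limit of > 500000 nM in this assay, at which 1 of the 2 values shown sits), so its true size is not fixed.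

Compound 3 `NC(=O)N(CCCCCCN1C[C@H](O)[C@@H](O)[C@H](O)[C@H]1CO)C1CCCCC1` is the next member. Its change from compound 2 is carbamoyl in place of phenylsulfonyl on an amine nitrogen. Among the compounds with values here, no measured step covers this change directly; the one step known, an at least 2.5-fold lower number from compound 1 to compound 2 (0.39 log units; beyond the scatter), shows that exchanging the aryl acyl group for phenylsulfonyl lowered the tolerated amount, and compound 3 removes the phenylsulfonyl again in favour of a small carbamoyl. On that basis compound 3 is expected to move back toward the high end, so the step of a 2.0-fold higher number from compound 2 to compound 3 (0.30 log units; within the scatter) is estimated as upward in this assay. For compound 3 the estimate in this assay is 400000 nM, within 150000 nM to 1000000 nM, with a fair chance that only a limit is reported.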

Compound 3, half-maximal cytotoxic concentration: > 500000 nM
Compound 3: no number, only a limit; the forecaster's own chance of this, stated with the estimate: 50%; at least 1.2-fold (0.09 log units) between middle value and limit.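

In this assay, carbamoyl in place of phenylsulfonyl on the amine nitrogen gives an at least 2.5-fold higher number from compound 2 to compound 3 (0.39 log units; beyond the scatter). The group on this nitrogen therefore moves the number in both directions, and the two groups that end at the limit differ widely: the (2,4,5-trifluorophenyl)carbonyl of compound 1 carries an aromatic ring, while the carbamoyl of compound 3 has no ring. Among these three compounds, an aromatic ring on this position does not by itself go with a lower number, as compound 1 shows, and only the phenylsulfonyl of compound 2 gives a plain value; the step from compound 1 to compound 3 cannot be read, and the readable steps give only minimum sizes: the limit of > 500000 nM in this assay, at which 2 of the 3 values shown sit.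

On these data alone, whether the lower number of compound 2 goes with the sulfonyl link or with its phenyl ring stays open, and a methylsulfonyl or a plain benzoyl group on the same amine nitrogen would separate the two. Also open, as far as these compounds go, is how the order of these groups would hold on a shorter chain to the polyhydroxylated ring.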